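Dichlorophenyl to dichloropyridinyl on the ring amine: solubility notes

The source may hold more compounds than are shown below. What is called first, only, known or untested is meant among the compounds shown, and "the series" means these compounds.

Compound 1 `N#Cc1cnc(NC(=O)N2CCN(c3ccc(Cl)c(Cl)c3)CC2)s1` is the reference point of this set. In a physicochemical assay for solubility, read by nephelometry, at pH 6.5 (a higher number here means a more soluble compound, a lower number a less soluble compound), compound 1 returns only a limit, < 1600 nM, not a number. The other measured members give numbers: compound 2 `Cc1ccc(N2CCN(C(=O)Nc3ncc(Cl)s3)CC2=O)cc1Cl` shows 1600 nM in this assay, and compound 3 `Clc1cnc2[nH]c(N3CCN(c4cnc(Cl)c(Cl)c4)CC3)nc2c1` shows 1600 nM in this assay; these two values lie within the scatter of each other, so no order between them can be read. Among the measured compounds shown here, the only evidence on the numbers is the limit of < 1600 nM in this assay, at which 1 of the 3 values shown sits, which places compound 1 at the floor of what the assay reports.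

Compound 4 `N#Cc1cnc(NC(=O)N2CCN(c3cnc(Cl)c(Cl)c3)CC2)s1` is the next compound, still unmeasured in this assay. It differs from compound 1 in one place: 5,6-dichloropyridin-3-yl in place of 3,4-dichlorophenyl on an amine nitrogen in a ring. For the measured compounds named here, no measured pair in this set isolates that change, so the size of its effect is open.

The expectation for compound 4 is a step from the limit of compound 1 that stays close to the scatter, a number no lower from compound 1 to compound 4 (the limit leaves the size open), with a fair chance that the assay again returns only a limit. Compound 4 is therefore estimated at 1600 nM in this assay, with a plausible range from 800 nM to 4000 nM.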

Compound 4, solubility: < 1600 nM
Compound 4: only a limit was reported (the forecaster's own chance of this, stated with the estimate: 45%); the middle value lies on the limit itself.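

Compound 1 and compound 4 both return only a limit in this assay, so no step can be read for 5,6-dichloropyridin-3-yl in place of 3,4-dichlorophenyl. The compounds shown leave open the size and direction of that change, because both readings rest on the same limit: the limit of < 1600 nM in this assay, at which 2 of the 4 values shown sit.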